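The compounds below may be only part of what the source reports. "The series", "measured", "known", "first", "only" and "open" are said of these compounds alone.

Measured in an ADME assay on MT2 cells (Homo sapiens) for cytotoxicity, read by MTT assay; on this read-out higher numbers stand for lower toxicity in this test and lower numbers for higher toxicity in this test:
compound 1, `Clc1cccc(Cl)c1Cc1nnc(Nc2ccc(COCc3ccccc3)cc2)o1`: 84000 nM
compound 2, `Clc1cccc(Cl)c1Cc1nnc(Nc2ccc(COCc3ccccn3)cc2)o1`: > 100000 nM

The two share one core and differ only at the saturated chain carbon bound to an oxygen on a saturated carbon. For compound 2 the value in this assay is a limit of the assay, not a number. This is the point (the limit of > 100000 nM in this assay, at which 1 of the 2 values shown sits). Of the two values shown, compound 2 thus stands at the limit end while compound 1 has a number, and the step of an at least 1.1-fold higher number from compound 1 to compound 2 (0.07 log units; that floor lies within the scatter) is only a floor. Compound 3, `Clc1cccc(Cl)c1Cc1nnc(Nc2ccc(COCc3ccncc3)cc2)o1`, is to be measured in this assay. Its difference from compound 2: pyridin-4-yl in place of pyridin-2-yl on a saturated chain carbon bound to an oxygen on a saturated carbon The two have the same atoms joined differently; cut one bond further out it reads (pyridin-2-yl)methoxy to (pyridin-4-yl)methoxy. Within the data shown here, only one measured step touches this site, the move to compound 2 just noted, and it was a floor within the scatter; no measured step exchanges one pyridinyl for another. No step beyond the scatter is therefore expected. For compound 3 the step expected is a number no higher from compound 2 to compound 3 (the limit leaves the size open). Compound 3 is expected to give 100000 nM, within 50000 nM to 250000 nM, most likely reported again as a limit.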

Compound 3, half-maximal cytotoxic concentration: 81000 nM
The estimate for compound 3 lay 1.2-fold (0.09 log units) above the measured number; the measured number falls inside the stated range.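

The exchange of phenyl for pyridin-4-yl on a saturated chain carbon bound to an oxygen on a saturated carbon now has a number at both ends in this assay, and it reads as a 1.0-fold lower number from compound 1 to compound 3 (0.02 log units; within the scatter). Moving the ring nitrogen, with the atoms otherwise unchanged, gives an at least 1.2-fold lower number from compound 2 to compound 3 (0.09 log units; that floor lies within the scatter). The value of compound 2 is a limit of the assay, so that step is only a floor and its full size stays unread: the limit of > 100000 nM in this assay, at which 1 of the 3 values shown sits.

Open is whether any group at this site gives a step beyond the scatter in this assay, since the phenyl, pyridin-2-yl and pyridin-4-yl groups shown give none, and whether pyridin-3-yl, a ring carrying an amine or a carboxylic acid, or a longer chain between the oxygen and the ring would behave in the same way. Also open is whether the same flat reading would hold with the shared core changed elsewhere, as all the compounds shown differ only at this one site.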